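The source may report more compounds than this note shows. Statements on the series, on what has been measured and on what is new or still open speak of the compounds shown alone.

Of the compounds shown here, three have so far been measured in a functional assay on Raji cells (Homo sapiens) for antiproliferative activity, read by CCK-8 assay, with a stated time of 72 h, tested at 40 uM; a lower number here means less inhibition, a higher number more inhibition at the concentration tested (going by the name of the read-out). Compound 1 `CCOC(=O)c1sc(-c2cccc(NC(=O)c3ccccc3)c2)nc1Nc1ccc(N2CCN(C)CC2)cc1` gives 42%. Compound 2 `CCOC(=O)c1sc(-c2cccc(NC(=O)c3cccc(F)c3)c2)nc1Nc1ccc(N2CCN(C)CC2)cc1` gives 82.8%, and compound 3 `CN1CCN(c2ccc(Nc3nc(-c4cccc(NC(=O)c5ccccc5)c4)sc3C(=O)O)cc2)CC1` gives 11.9%, the lowest of the three numbers, well apart from both of the others. Two single changes connect these compounds. Putting hydrogen in place of ethyl on the oxygen next to the carbonyl group gave a number 30.1 percentage points lower from compound 1 to compound 3 (beyond the scatter). Putting fluoro in place of hydrogen on an aromatic carbon gave a number 40.8 percentage points higher from compound 1 to compound 2 (beyond the scatter), a large rise.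

Compound 4 `CN1CCN(c2ccc(Nc3nc(-c4cccc(NC(=O)c5cccc(F)c5)c4)sc3C(=O)O)cc2)CC1` is compound 3 carrying that same fluoro change: fluoro in place of hydrogen on an aromatic carbon. Among the measured compounds shown here, the only measured step that bears on it is the one from compound 1 to compound 2, which was large and upward; no measured pair shows the fluoro change made on a compound that already carries the hydrogen on the oxygen next to the carbonyl group. A rise of that general kind is therefore expected, with the step for compound 4 estimated at a number 30.1 percentage points higher from compound 3 to compound 4 (beyond the scatter). The estimate for compound 4 in this assay is 42%, expected to fall between 18% and 68%.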

Compound 4, a percentage reported as inhibition, at one concentration (the size of the read-out at that concentration, not a potency): 76.3%
For compound 4 the middle estimate is 34.3 percentage points below the measured one; the whole stated range lies below it.
By their numbers in this assay, from the lowest: compound 3; then compound 1; then compounds 4 and 2 (each within the scatter of the next).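

The fluoro change raises the number on the carboxylic acid as well as on the ethyl ester, and the step is larger on the acid: the same change on two cores in this assay, a number 40.8 percentage points higher (beyond the scatter) from compound 1 to compound 2 and a number 64.4 percentage points higher (beyond the scatter) from compound 3 to compound 4, 23.6 percentage points apart, beyond the scatter of two such steps. With the 3-fluorophenyl group in place, hydrogen in place of ethyl gives a number 6.5 percentage points lower from compound 2 to compound 4 (within the scatter), and the fluoro step on the acid is a number 64.4 percentage points higher from compound 3 to compound 4 (beyond the scatter). The two changes therefore do not simply add up, as the ethyl change has a different effect depending on which benzamido group is present: the same change on two cores in this assay, a number 30.1 percentage points lower (beyond the scatter) from compound 1 to compound 3 and a number 6.5 percentage points lower (within the scatter) from compound 2 to compound 4, 23.6 percentage points apart, beyond the scatter of two such steps.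

Going by these compounds, it remains open whether chloro, methoxy or an amine in place of the fluoro would give a similar rise, or whether fluoro on another carbon of this ring would do so. Also open, on these data alone, is whether the fluoro step holds with a longer chain than ethyl on that oxygen.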